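One Aryl Swap Repeated on a Second Core

The compounds below may be only part of what the source reports. "The series", "measured", "known", "first", "only" and "open" are said of these compounds alone.

Measured so far in an ADME assay on microsomes from liver (Mus musculus) for metabolic stability; a lower number here means slower removal, a higher number faster removal of the compound:
Compound 1 `COc1cc([C@](O)(CCN(C)C)[C@@H](c2cc3cc(Br)ccc3nc2OC)c2cccc(OC)c2F)cc(OC(F)F)n1` gives 6.4 uL/min.
Compound 2 `COc1cc([C@](O)(CCN(C)C)[C@@H](c2cc3cc(Br)ccc3nc2OC)c2ccnc(OC)c2OC)cc(OC(F)F)n1` gives 4.9 uL/min.
Compound 3 `COc1cccc([C@H](c2cc3cc(Br)ccc3nc2OC)[C@@](O)(CCN(C)C)c2cc(SC)nc(SC)c2)c1F` gives 17 uL/min.

Compound 4 `COc1nc2ccc(Br)cc2cc1[C@@H](c1ccnc(OC)c1OC)[C@@](O)(CCN(C)C)c1cc(SC)nc(SC)c1` has not yet been measured. It differs from compound 3 by 2,3-dimethoxypyridin-4-yl in place of 2-fluoro-3-methoxyphenyl on a saturated chain carbon bound to an aromatic carbon and a saturated chain carbon. The same swap separates compound 1 from compound 2, and there it produced a 1.3-fold lower number from compound 1 to compound 2 (0.12 log units; within the scatter). The two pairs sit on different cores: compound 3 differs from compound 1 by a group of 10 heavy atoms (7 carbon, 1 nitrogen, 2 sulfur; one six-membered aromatic ring with 1 hetero atom) in place of a group of 12 heavy atoms (7 carbon, 1 nitrogen, 2 oxygen, 2 fluorine; one six-membered aromatic ring with 1 hetero atom), on a saturated chain carbon bound to an oxygen on a saturated carbon and two saturated chain carbons, a change that brought a 2.7-fold higher number from compound 1 to compound 3 (0.42 log units; beyond the scatter). The place of the aryl swap is worded identically in both pairs. Within the data shown here, the move from compound 3 to compound 4 is thus the same change as the one from compound 1 to compound 2, only made on the other core. Among the measured compounds shown here, whether that core alters the outcome cannot be read from these three compounds, since only one measured example of the swap exists. A step of similar size is expected for compound 4, namely a 1.3-fold lower number from compound 3 to compound 4 (0.12 log units; within the scatter), because the same swap gave a 1.3-fold lower number from compound 1 to compound 2 (0.12 log units; within the scatter). Compound 4 is therefore estimated at 13 uL/min in this assay, expected to fall between 7 uL/min and 25 uL/min.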

Compound 4, intrinsic clearance in a liver preparation (reported as CLH), per the amount of preparation that the assay uses: 10 uL/min
Estimate against measurement, compound 4: 1.3-fold (0.11 log units) above, and the stated range covers the measured number.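

In this assay, replacing 2-fluoro-3-methoxyphenyl with 2,3-dimethoxypyridin-4-yl gives a 1.7-fold lower number from compound 3 to compound 4 (0.23 log units; within the scatter), and this step agrees with the same swap on the other core: the same change on two cores in this assay, a 1.3-fold lower number (0.12 log units; within the scatter) from compound 1 to compound 2 and a 1.7-fold lower number (0.23 log units; within the scatter) from compound 3 to compound 4, 1.3-fold (0.11 log units) apart, within the scatter of two such steps. The change between the two cores gives a 2.0-fold higher number from compound 2 to compound 4 (0.31 log units; beyond the scatter), and it also carries over with the aryl group swapped: the same change on two cores in this assay, a 2.7-fold higher number (0.42 log units; beyond the scatter) from compound 1 to compound 3 and a 2.0-fold higher number (0.31 log units; beyond the scatter) from compound 2 to compound 4, 1.3-fold (0.11 log units) apart, within the scatter of two such steps. Among these compounds, in these four compounds the two changes therefore look independent of each other, but this rests on only two pairs, and since both swap steps lie within the scatter, they do not show that the swap itself shifts the number at all.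

Going by these compounds, it remains open whether the agreement would hold on a third core, or with a different group at the same place, such as a plain phenyl or a ring carrying a nitrile. The compounds shown also leave open what a longer chain in place of the one bearing the dimethylamino group would do to these steps.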